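A few compounds are considered here, and "the series" means these few. Any claim that something is new, unique, unknown or untested is made for them only; others in the source may bear on it.

Measured compounds:
Compound 1, `CCOC(=O)c1ccc(-c2nn(Cc3cccnc3)c3ccccc23)cc1`: in a functional assay on cells (Platelet, Homo sapiens) for inhibition (a higher number here means a weaker inhibitor, a lower number a stronger inhibitor), compound 1 gives > 10000 nM, which is a limit of the assay and not a number.
Compound 2, `CCCCn1nc(-c2ccc(C(=O)OCC)cc2)c2ccccc21`: in this assay compound 2 gives > 10000 nM, again a limit and not a number.

Among the compounds with values here, compound 2 therefore stands without a measured number; it sits at the limit of > 10000 nM in this assay, at which 2 of the 2 values shown sit, and so does the only other measured compound. Within the data shown here, the one measured step, from compound 1 to compound 2, reads a step that the two limits leave unreadable from compound 1 to compound 2. Its size is not readable: both of its values are limits, so neither direction nor magnitude can be drawn from it.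

Compound 3, `CCOC(=O)c1ccc(-c2nn(-c3ccccc3)c3ccccc23)cc1`, differs from compound 2 by phenyl in place of butyl on an aromatic nitrogen. Among the measured compounds shown here, no measured step bears on this change with a readable size, and so nothing in the data points either way. The expectation for compound 3 rests only on where compound 2 stands, and compound 3 is estimated at 20000 nM in this assay, with a range from 3000 nM to 100000 nM. The step this estimate means, a step that the limit leaves unreadable from compound 2 to compound 3, is expected to be none beyond the scatter, and the result may again be reported only as a limit.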

Compound 3, half-maximal inhibitory concentration: > 10000 nM
Compound 3: only a limit was reported; the forecaster's own chance of this, stated with the estimate: 80%; the middle value does not contradict the limit.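

In this assay compound 3 gives > 10000 nM, a limit of the assay and not a number. The steps from compound 1 and from compound 2 to compound 3 therefore cannot be read, and all three compounds stand together: the limit of > 10000 nM in this assay, at which 3 of the 3 values shown sit. The compounds shown leave open whether any group on this aromatic nitrogen gives a measurable inhibition.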